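Difluoromethoxy Replaces Fluoro on the Aryl Group

A few compounds are considered here, and "the series" means these few. Any claim that something is new, unique, unknown or untested is made for them only; others in the source may bear on it.

Compound 1, `COc1ccc(-n2c(C)nc3c(NC(C4CC4)C4CC4)nc(C)nc32)c(C)c1`: 14 nM
Compound 2, `Cc1nc(NC(C2CC2)C2CC2)c2nc(C)n(-c3ccc(Cl)cc3)c2n1`: 11 nM
Compound 3, `Cc1nc(NC(C2CC2)C2CC2)c2nc(C)n(-c3ccc(F)cc3)c2n1`: 91 nM

All three were measured in a functional assay on CHO cells for antagonist activity at corticotropin-releasing factor receptor 1 (Homo sapiens), read by cAMP accumulation; a lower number here means a stronger inhibitor, a higher number a weaker inhibitor. Compound 3 has the highest number of the three: the step of a 6.5-fold higher number from compound 1 to compound 3 (0.81 log units; beyond the scatter) and the step of an 8.3-fold higher number from compound 2 to compound 3 (0.92 log units; beyond the scatter) both lie beyond the scatter, while the step of a 1.3-fold lower number from compound 1 to compound 2 (0.10 log units; within the scatter) does not.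

Compound 4, `Cc1nc(NC(C2CC2)C2CC2)c2nc(C)n(-c3ccc(OC(F)F)cc3)c2n1`, has not been measured. It differs from compound 3 by difluoromethoxy in place of fluoro on an aromatic carbon. Among the measured compounds shown here, the steps that bear on this change are an 8.3-fold higher number from compound 2 to compound 3 (0.92 log units; beyond the scatter) and a 6.5-fold higher number from compound 1 to compound 3 (0.81 log units; beyond the scatter): both show that the fluoro group at this place goes with the higher number, and that both the chloro group and the methoxy-bearing aryl group go with a markedly lower number. The difluoromethoxy group, with its four heavy atoms, is closer in extent to those groups than to fluoro, so a lower number is expected for compound 4 in this assay, estimated as a 4.6-fold lower number from compound 3 to compound 4 (0.66 log units; beyond the scatter). The expected value for compound 4 is 20 nM, within a range of 6 nM to 60 nM.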

Compound 4, inhibition constant: 5 nM
Compound 4: middle estimate off by 4.0-fold (0.60 log units), on the high side; the whole stated range lies above it.
By their numbers in this assay, from the lowest: compound 4; then compounds 2 and 1 (each within the scatter of the next); then compound 3.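

In this assay, replacing fluoro with difluoromethoxy at this place gives an 18-fold lower number from compound 3 to compound 4 (1.26 log units; beyond the scatter), so a group of four heavy atoms on this aromatic carbon is not only accepted but goes with a much lower number. The chloro group does not mark the low end at this place either, since a 2.2-fold lower number from compound 2 to compound 4 (0.34 log units; beyond the scatter) puts difluoromethoxy ahead of it, and the three groups now stand in the order difluoromethoxy, chloro, fluoro. No evidence available here explains why these groups differ.

The compounds shown leave open whether the oxygen or the two fluorines carry this change, which a plain methoxy group or a trifluoromethoxy group at the same place would help to separate. From the compounds shown here alone, how an amine there would compare also remains open.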